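The compounds below may be only part of what the source reports. "The series", "measured", "known", "first", "only" and "open" are said of these compounds alone.

Three compounds share one core and differ only in the group on the amide-type nitrogen. Compound 1 `O=C(CCC(=O)OCCCCCCSc1ccc([N+](=O)[O-])c2nonc12)Nc1ccccc1F` carries a 2-fluorophenyl there, and in an assay on isolated protein for inhibition of glutathione S-transferase P (Homo sapiens), with a stated time of 10 min (on this read-out higher numbers stand for weaker inhibition and lower numbers for stronger inhibition), compound 1 gives 9890 nM. Compound 2 `O=C(CCC(=O)OCCCCCCSc1ccc([N+](=O)[O-])c2nonc12)Nc1ccc(F)cc1` carries a 4-fluorophenyl, and in this assay compound 2 gives 8570 nM. Compound 3 `O=C(CCC(=O)OCCCCCCSc1ccc([N+](=O)[O-])c2nonc12)Nc1ccc(Br)cc1` carries a 4-bromophenyl, and in this assay compound 3 gives 5090 nM. Compound 3 has the lowest of the three numbers, but the gaps to the other two, a 1.9-fold lower number from compound 1 to compound 3 (0.29 log units; within the scatter) and a 1.7-fold lower number from compound 2 to compound 3 (0.23 log units; within the scatter), both stay inside the scatter, as does a 1.2-fold lower number from compound 1 to compound 2 (0.06 log units; within the scatter), so the three compounds cannot be told apart on these numbers.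

Compound 4 `COc1ccc(NC(=O)CCC(=O)OCCCCCCSc2ccc([N+](=O)[O-])c3nonc23)cc1` is not yet measured. It keeps the core and the amide and changes one thing: methoxy in place of bromo on an aromatic carbon, the new group sitting para to a large group. Among the measured compounds shown here, the one measured step at that same place, a 1.7-fold lower number from compound 2 to compound 3 (0.23 log units; within the scatter), swapped one halogen for another and moved the number by less than the scatter. For the measured compounds named here, no measured step tells what a methoxy does there. The expectation for compound 4 in this assay is therefore a step of about a 1.4-fold higher number from compound 3 to compound 4 (0.14 log units; within the scatter), meaning no change beyond the scatter. Compound 4 is estimated at 7000 nM, with a range from 3500 nM to 14000 nM.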

Compound 4, half-maximal inhibitory concentration: 420 nM
Compound 4: the middle estimate sits 17-fold (1.22 log units) above what was measured; the measured number lies below the stated range.
By their numbers in this assay, from the lowest: compound 4; then compounds 3, 2 and 1 (each within the scatter of the next).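

At the aromatic carbon para to a large group, the earlier halogen swap showed almost no response in this assay, yet this position turns out to be highly sensitive to what sits there: methoxy in place of bromo gives a 12-fold lower number from compound 3 to compound 4 (1.08 log units; beyond the scatter) and is a clear change, and methoxy in place of fluoro gives a 20-fold lower number from compound 2 to compound 4 (1.31 log units; beyond the scatter) at the same place. Among the compounds shown here, measured against the only compound with its fluoro elsewhere on the ring, the change to 4-methoxyphenyl gives a 24-fold lower number from compound 1 to compound 4 (1.37 log units; beyond the scatter), which sets compound 4 apart from all three earlier compounds, not just from its closest neighbour. Methoxy differs from bromo by one more heavy atom and by one hydrogen-bond acceptor where bromo has none, but no evidence at hand tells which feature of methoxy, if any, accounts for the result.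

The compounds shown leave open whether the oxygen alone is enough or the attached carbon is needed as well, which a hydroxy, an ethoxy or an amine at the same place would help to separate. They also leave open whether the 4-methoxyphenyl group keeps its effect when a longer chain replaces the one in the shared core.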